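A few compounds are considered here, and "the series" means these few. Any claim that something is new, unique, unknown or untested is made for them only; others in the source may bear on it.

Working notes on the hydroxamic acid series in a functional assay on ACHN cells (Homo sapiens) for antiproliferative activity; on this read-out lower numbers stand for stronger inhibition of growth and higher numbers for weaker inhibition of growth.

Three compounds carry the shared core with a benzyl substituent. Compound 1 `O=C(CCC1=CCN(Cc2ccc(C(F)(F)F)cc2)C1=O)NO` bears a trifluoromethyl on the aromatic ring and in this assay gives 4290 nM. Compound 2 `COc1cccc(CN2CC=C(CCC(=O)NO)C2=O)c1` bears a methoxy and in this assay gives 4430 nM; this is the highest of the two numbers, and compound 1 sits so close that the two values lie within the scatter of each other. Within the data shown here, for compound 3 `COc1ccccc1CN1CC=C(CCC(=O)NO)C1=O` the assay reports only a limit, > 10000 nM, not a number; it is the one value sitting at the limit of > 10000 nM in this assay, at which 1 of the 3 values shown sits.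

Compound 4 `O=C(CCC1=CCN(Cc2cccc(C(F)(F)F)c2)C1=O)NO` is not yet measured. It differs from compound 2 by trifluoromethyl in place of methoxy on an aromatic carbon, so a trifluoromethyl in place of methoxy on an aromatic carbon. Among the measured compounds shown here, no measured pair shows this exact exchange. Compound 1 shows that a trifluoromethyl on the same ring is compatible with the number it gives, and so no step beyond the scatter is expected from compound 2 to compound 4, a 1.1-fold lower number from compound 2 to compound 4 (0.04 log units; within the scatter). Compound 4 is therefore estimated at 4000 nM, with a plausible range from 1500 nM to 12000 nM.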

Compound 4, concentration for 50% growth inhibition: 670 nM
Beside the measured number, compound 4's estimate is 6.0-fold (0.78 log units) above it; the whole stated range lies above it.
By their numbers in this assay, from the lowest: compound 4; then compounds 1 and 2 (each within the scatter of the next). At a limit, above all of these: compound 3.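

In this assay, the exchange of methoxy for trifluoromethyl on an aromatic carbon, meta to a large group, gives a 6.6-fold lower number from compound 2 to compound 4 (0.82 log units; beyond the scatter) and so is not neutral at this position. Compound 1, with its trifluoromethyl elsewhere on the same ring, gives 4290 nM while compound 4 gives 670 nM on the same read-out, which shows that the place of the group on the ring matters in these two compounds, something the closeness of compound 1 and compound 2 could not reveal. Nothing in the evidence at hand bears on the reason for this step.

On these data alone, whether other groups at this position, such as a nitrile or a carboxylic acid, would match compound 4 stays open. Also open, as far as these compounds go, is whether this step would hold with a longer chain carrying the hydroxamic acid.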